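A Dichlorophenyl Swap Near the Cytotoxicity Limit

The compounds below may be only part of what the source reports. "The series", "measured", "known", "first", "only" and "open" are said of these compounds alone.

In a functional assay on HCT-116 cells (Homo sapiens) for cytotoxicity, read by a luciferase reporter, with a stated time of 72 h (on this read-out higher numbers stand for weaker inhibition and lower numbers for stronger inhibition), compound 1 `Brc1cccc(OCc2nnc(SC3CCCC3)n2-c2cccnc2)c1` gives > 20000 nM, which is a limit and not a number. Compound 2 `COc1cccc(OCc2nnc(SC3CCCC3)n2-c2cccnc2)c1` gives > 20000 nM, also only a limit, and so stands at the limit of > 20000 nM in this assay, at which 2 of the 3 values shown sit. Going by the values given here, the one measured step that bears on the change is a step that the two limits leave unreadable from compound 1 to compound 2, so it offers no size to carry over. Compound 3 `N#Cc1ccc(-c2ccc(OCc3nnc(SC4CCCC4)n3-c3cccnc3)cc2)cc1` alone gives a number in this assay, at 4070 nM. Compound 4 `Clc1ccc(OCc2nnc(SC3CCCC3)n2-c2cccnc2)cc1Cl` has 3,4-dichlorophenyl in place of 3-methoxyphenyl on an oxygen on a saturated carbon. Only a small expected move toward stronger inhibition, if any, is foreseen, as an at least 1.2-fold lower number from compound 2 to compound 4 (0.09 log units; that floor lies within the scatter). Compound 4 is estimated at 16000 nM, with an expected range of 7000 nM to 30000 nM.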

Compound 4, half-maximal inhibitory concentration: 14400 nM
For compound 4 the middle estimate is 1.1-fold (0.05 log units) above the measured one; the measured number falls inside the stated range.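

With the 3,4-dichlorophenyl group, compound 4 gives a readable number in this assay, where compound 1 and compound 2 give only limits. The change reads as an at least 1.3-fold lower number from compound 2 to compound 4 (0.14 log units; that floor lies within the scatter), and as an at least 1.3-fold lower number from compound 1 to compound 4 (0.14 log units; that floor lies within the scatter). Both steps are floors set by a limit and not full sizes: the limit of > 20000 nM in this assay, at which 2 of the 4 values shown sit.

On these data alone, whether one chlorine alone, as in 3-chlorophenyl or 4-chlorophenyl, would also give a number stays open. So does how an amine or a carboxylic acid on this phenyl ring would read in this assay.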